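This account rests on a few compounds, and the source may have more. Where it says the series, first, only, none or still open, it means among the compounds named here.

Among the compounds with values here, compound 1, `O=C1C(Nc2ccc(I)cc2)=CC(=O)c2c1nc1n2[C@H]2OC[C@@H](O)[C@H]2OC1`, is the first of the pair that fixes the scale here. In a functional assay on HeLa cells (Homo sapiens) for inhibition, read by sulforhodamine B assay (on this read-out higher numbers stand for weaker inhibition and lower numbers for stronger inhibition), compound 1 gives 4010 nM. Compound 2, `O=C1C(N2CCCCC2)=CC(=O)c2c1nc1n2[C@H]2OC[C@@H](O)[C@H]2OC1`, carries the change (piperidin-1-yl in place of (4-iodophenyl)amino on a double-bonded ring carbon). In this assay compound 2 reaches only the limit of > 16000 nM, which is a limit of the assay and not a number. The step is an at least 3.9-fold higher number from compound 1 to compound 2 (0.60 log units; beyond the scatter), and its size can only be stated as a lower bound because of the limit of > 16000 nM in this assay, at which 1 of the 3 values shown sits.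

Compound 3, `O=C1C=C(Nc2ccc(I)cc2)C(=O)c2c1nc1n2[C@H]2OC[C@@H](O)[C@H]2OC1`, is built from the same atoms as compound 1, joined differently; the difference between the two cores is not broken down here. In this assay compound 3 gives 4070 nM, a value that sits within the scatter of compound 1, so no order between the two is claimed.

Compound 4, `O=C1C=C(N2CCCCC2)C(=O)c2c1nc1n2[C@H]2OC[C@@H](O)[C@H]2OC1`, has not yet been measured in this assay. Within the data shown here, it stands to compound 3 as compound 2 stands to compound 1: the change is piperidin-1-yl in place of (4-iodophenyl)amino on a double-bonded ring carbon, the same change, at the same place, as the one between compound 1 and compound 2. On that single earlier step the expected step is a 4.9-fold higher number from compound 3 to compound 4 (0.69 log units; beyond the scatter), a loss of at least the size seen from compound 1 to compound 2. For compound 4 the expected value in this assay is therefore 20000 nM, with an expected range from 8000 nM to 60000 nM, and a real chance that only a limit is reported.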

Compound 4, half-maximal inhibitory concentration: > 16000 nM
Compound 4 was reported as a limit; the forecaster's own chance of this, stated with the estimate: 60%; the middle value does not contradict the limit.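

In this assay, putting piperidin-1-yl in place of (4-iodophenyl)amino on the second core gives an at least 3.9-fold higher number from compound 3 to compound 4 (0.59 log units; beyond the scatter), so the loss of inhibition seen on the core of compound 1 appears again, and the direction of this change carries over in both pairs shown: the same change on two cores in this assay, an at least 3.9-fold higher number (0.60 log units; beyond the scatter) from compound 1 to compound 2 and an at least 3.9-fold higher number (0.59 log units; beyond the scatter) from compound 3 to compound 4; the limit leaves it open whether they differ Compound 4 is recorded only as > 16000 nM, which is a limit of the assay and not a number. The result therefore does not show how large either step really is, or whether the change costs the same on both cores, because the values of both piperidin-1-yl compounds stop at that limit: the limit of > 16000 nM in this assay, at which 2 of the 4 values shown sit.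

The compounds shown leave open which part of the (4-iodophenyl)amino group goes with the stronger inhibition of compound 1 and compound 3, since the iodine, the aromatic ring and the amide-like hydrogen on the nitrogen all leave together in this change. A plain phenylamino group, an open-chain amine such as diethylamino, or a morpholine ring on either core would separate these parts, and the series as shown cannot say how such groups would read in this assay.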